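The compounds below may be only part of what the source reports. "The series", "measured", "known", "first", "only" and "open" are said of these compounds alone.

Compound 1, with the structure `COc1ccc(CNc2nc([Se]C)nc3ccccc23)cc1`, stands at the edge of what the test can report. In a functional assay on HT-29 cells (Homo sapiens) for cytotoxicity, read by MTT assay, with a stated time of 72 h (on this read-out lower numbers stand for higher toxicity in this test and higher numbers for lower toxicity in this test), compound 1 gives > 100000 nM, which is a limit of the assay and not a number. Compound 3, with the structure `C[Se]c1nc(NCc2ccccc2)c2ccccc2n1`, is another of the measured compounds, and in this assay compound 3 gives > 100000 nM, again a limit. Compound 2, with the structure `CCCCC[Se]c1nc([Se]CCCCC)c2ccccc2n1`, gives > 100000 nM in this assay, likewise a limit. Among the measured compounds shown here, the only step between measured compounds that differ in one place is a step that the two limits leave unreadable from compound 1 to compound 3, a hydrogen in place of a methoxy on an aromatic carbon, and its size cannot be read because the limit of > 100000 nM in this assay, at which 3 of the 3 values shown sit, holds all three measured values at the same limit.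

Compound 4, with the structure `COc1ccc(CNc2nc(SC)nc3ccccc23)cc1`, has not yet been measured. It differs from compound 1 by a group of 2 heavy atoms (1 carbon, 1 sulfur; no ring) in place of a group of 2 heavy atoms (1 carbon, 1 selenium; no ring), on an aromatic carbon. For the measured compounds named here, no measured step touches this exchange, and the one step that exists is unreadable, so nothing here points to a change in either direction. Compound 4 is therefore expected to sit at the limit as well, with an estimated value of 150000 nM and a range from 50000 nM to 500000 nM. The expected step that the limit leaves unreadable from compound 1 to compound 4 is one of no readable movement from the limit.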

Compound 4, concentration lethal to 50% of the cells: > 100000 nM
Compound 4: only a limit was reported; the forecaster's own chance of this, stated with the estimate: 80%; the middle value does not contradict the limit.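

In this assay compound 4 gives > 100000 nM and this is a limit, not a number. Among the compounds shown here, no step between compound 1 and compound 4 can be read, because both sit at the same limit: the limit of > 100000 nM in this assay, at which 4 of the 4 values shown sit.

The compounds shown leave open how toxic any of them is to these cells, and whether methylsulfanyl and the selenium-bearing group it replaces differ at all.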